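Aryl Variation at the Ring Nitrogen: Compound 3 to Compound 4

The source may hold more compounds than are shown below. What is called first, only, known or untested is meant among the compounds shown, and "the series" means these compounds.

The series is compared in a functional assay on MGC-803 cells (Homo sapiens) for inhibition, read by MTT assay, with a stated time of 72 h; a higher number here means a weaker inhibitor, a lower number a stronger inhibitor. Compound 1 `O=C(CSc1nc(Nc2ccccc2)c2ccccc2n1)Nc1ccc(F)cc1` differs from the later compounds in more than one place and is not part of any single-change step. For compound 1 this assay reports only a limit, > 50000 nM.

Compound 2 `C=CC(=O)Nc1cccc(NC(=O)CSc2nc(Nc3cccc(Br)c3)c3ccccc3n2)c1` gives 11900 nM in this assay, and compound 3 `C=CC(=O)Nc1cccc(NC(=O)CSc2nc(Nc3cccc(OC)c3)c3ccccc3n2)c1` gives 24200 nM. The step between them is a 2.0-fold higher number from compound 2 to compound 3 (0.31 log units; beyond the scatter). Among the two numbers shown, compound 3 carries the higher one, with compound 2 its nearest neighbour; the third value shown is the limit for compound 1.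

Compound 4 `C=CC(=O)Nc1cccc(NC(=O)CSc2nc(Nc3ccc(Cl)cc3Cl)c3ccccc3n2)c1` is the next single-change step from compound 3: 2,4-dichlorophenyl in place of 3-methoxyphenyl on a nitrogen on an aromatic ring. For the measured compounds named here, the only measured step touching this position is a 2.0-fold higher number from compound 2 to compound 3 (0.31 log units; beyond the scatter), in which a halogen gave way to the methoxy group and the number rose. The present change runs the other way, returning halogens in place of the methoxy, so a modest lowering of the number is expected, though the 2,4-dichlorophenyl pattern with two chlorines is not covered by any measured pair and the size is uncertain. The step from compound 3 is expected to be a 2.0-fold lower number from compound 3 to compound 4 (0.30 log units; within the scatter). Compound 4 is therefore estimated at 12000 nM, with a range from 4000 nM to 40000 nM.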

Compound 4, half-maximal inhibitory concentration: 12100 nM
The estimate for compound 4 lay 1.0-fold (0.00 log units) below the measured number; measured number inside the range.
By their numbers in this assay, from the lowest: compounds 2, 4 and 3 (each within the scatter of the next, the first and the last beyond it). At a limit, above all of these: compound 1.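

In this assay, the step to the new aryl group on the nitrogen is a 2.0-fold lower number from compound 3 to compound 4 (0.30 log units; within the scatter), and the step from the bromo compound is a 1.0-fold higher number from compound 2 to compound 4 (0.01 log units; within the scatter). The 2,4-dichlorophenyl group therefore cannot be separated from either 3-methoxyphenyl or 3-bromophenyl, although those two groups are themselves separated by a 2.0-fold higher number from compound 2 to compound 3 (0.31 log units; beyond the scatter), so two chlorines in this pattern read the same as one bromine within the scatter, and the 2,4-dichlorophenyl group sits in the middle of a narrow span rather than extending it. Nothing shown gives a cause for these small differences at this position.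

Compound 1 remains a limit, > 50000 nM, and it differs from the other compounds in more than one place, so it cannot be read as a step at this position. Open questions are whether a carboxylic acid or an amine on this phenyl ring would move the number further than the steps seen here, and whether a single chlorine would read apart from the 2,4-dichlorophenyl group.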